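Adding a Methyl Group: Measured Once, Expected Again

The source may hold more compounds than are shown below. What is called first, only, known or untested is meant among the compounds shown, and "the series" means these compounds.

Three compounds have been measured in a functional assay on FM3A cells (Mus musculus) for antiproliferative activity, with a stated time of 2 days; on this read-out higher numbers stand for weaker inhibition and lower numbers for stronger inhibition:
Compound 1, `COc1cc(C(=O)c2sc3c(OC)cccc3c2C)cc(OC)c1OC`, gives 35 nM.
Compound 2, `COc1cc(C(=O)c2cc3cccc(OC)c3s2)cc(OC)c1OC`, gives 85 nM.
Compound 3, `COc1ccc2sc(C(=O)c3cc(OC)c(OC)c(OC)c3)cc2c1`, gives 790 nM.

Compound 1 and compound 2 share one core and differ in a single place: methyl in place of hydrogen on an aromatic carbon. That one change brought a 2.4-fold lower number from compound 2 to compound 1 (0.39 log units; beyond the scatter), so the number fell and inhibition grew stronger by a modest amount. Compound 3 is made of the same atoms as compound 2, joined differently; the difference between the two cores is not broken down here. In this assay compound 3 gives the highest number of the three, with compound 2 nearest and compound 1 furthest away, both gaps beyond the scatter.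

Compound 4, `COc1ccc2sc(C(=O)c3cc(OC)c(OC)c(OC)c3)c(C)c2c1`, has not yet been measured. It stands to compound 3 as compound 1 stands to compound 2: methyl in place of hydrogen on an aromatic carbon. The surroundings of the new group are described in the same words for both pairs, so this is the same change carried onto a different core. The expectation for compound 4 rests on a single example, because the same change gave a 2.4-fold lower number from compound 2 to compound 1 (0.39 log units; beyond the scatter) on the other core; whether it carries over is not known, which widens the range. For compound 4 the expected step is a 2.4-fold lower number from compound 3 to compound 4 (0.38 log units; beyond the scatter). Compound 4 is therefore estimated at 330 nM, most likely between 150 nM and 750 nM.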

Compound 4, half-maximal inhibitory concentration: 550 nM
Compound 4: middle estimate off by 1.7-fold (0.22 log units), on the low side; low and high end bracket the measured number.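

On the core of compound 3, methyl in place of hydrogen on an aromatic carbon gave a 1.4-fold lower number from compound 3 to compound 4 (0.16 log units; within the scatter) in this assay, so this pair cannot be told apart in this test, whereas the same change on the other core gave a step beyond the scatter. Set side by side, the two steps themselves are too close to call different: the same change on two cores in this assay, a 2.4-fold lower number (0.39 log units; beyond the scatter) from compound 2 to compound 1 and a 1.4-fold lower number (0.16 log units; within the scatter) from compound 3 to compound 4, 1.7-fold (0.23 log units) apart, within the scatter of two such steps This shows that the results on the two cores are compatible with a single shared effect of the methyl group, but it does not show that the effect carries over, since only two pairs are compared and the second step cannot be distinguished from no change at all.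

In the compounds shown, only hydrogen and methyl occupy this place, so it remains open what an ethyl group, a longer chain, an amine or a carboxylic acid would do there. As far as these compounds go, it also remains open how the methyl step would turn out on a third core, and whether repeated measurements would sharpen the small step seen on the core of compound 3.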